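The compounds below may be only part of what the source reports. "The series", "measured", "known", "first", "only" and "open" are said of these compounds alone.

Measured in a functional assay (uterus) for inhibition, with Rattus norvegicus as the target; on this read-out higher numbers stand for an effect only at larger amounts of compound and lower numbers for an effect already at smaller amounts:
- Compound 1 `ClCc1cn2ccncc2n1`: 1.4 nM
- Compound 2 `CCOC(=O)c1cn2cc(Br)nc(Br)c2n1`: 0.15 nM
- Compound 3 `CCOC(=O)c1c(C)nc2cnccn12`: 0.152 nM

Compound 1 has the highest number of the three, and its gaps to compound 2 and compound 3 both lie beyond the usual scatter. The next compound to be tested is compound 4 `NC(=O)c1cn2ccncc2n1`, which has carbamoyl in place of chloromethyl on an aromatic carbon, next to the ring nitrogen: carbamoyl in place of chloromethyl on an aromatic carbon. Among the measured compounds shown here, no pair of measured compounds differs in one place only, so no direct precedent exists for this change. Compound 2 at 0.15 nM and compound 3 at 0.152 nM both carry a carbonyl in an ethyl ester, but each also differs from compound 1 elsewhere, which gives only weak support for a downward move. In this assay, the expected result is a small downward step that stays within the scatter: a 1.4-fold lower number from compound 1 to compound 4 (0.15 log units; within the scatter). For compound 4 the estimated value is 1 nM, with an expected range from 0.15 nM to 7 nM.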

Compound 4, concentration for half-maximal effect: 1.5 nM
Beside the measured number, compound 4's estimate is 1.5-fold (0.18 log units) below it; low and high end bracket the measured number.
By their numbers in this assay, from the lowest: compounds 2 and 3 (each within the scatter of the next); then compounds 1 and 4 (each within the scatter of the next).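

Among the compounds shown here, with a 1.1-fold higher number from compound 1 to compound 4 (0.03 log units; within the scatter) in this assay, carbamoyl in place of chloromethyl on an aromatic carbon, next to the ring nitrogen, gives the first direct reading at this position. The position therefore accepts two quite different groups on the core of compound 1 without a change beyond the scatter, even though carbamoyl brings in a hydrogen-bond donor and acceptor that chloromethyl lacks. No measurement at hand bears on why the two groups read alike.

Still open, from the compounds shown here alone, is how a carboxylic acid, an aminomethyl group or a longer chain would read at this same carbon on that core. Also open, going by these compounds, is whether an ethyl ester there, on the core of compound 1 and with no other change, would read like compound 1 or compound 4.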